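Swapping the dimethoxyphenyl group for a fused bicyclic ring

This account rests on a few compounds, and the source may have more. Where it says the series, first, only, none or still open, it means among the compounds named here.

Compound 1 `O=C(NNc1ccnc2cc(Cl)ccc12)c1ccccc1/N=C/c1ccc(Cl)cc1Cl` gives 6.22 in a physicochemical assay for lipophilicity, measured as octanol-water partition; a higher number here means a more lipophilic compound, a lower number a more polar compound.
Compound 2 `COc1ccc(/C=N/c2ccccc2C(=O)NNc2ccnc3cc(Cl)ccc23)cc1OC` gives 4.97 in this assay.
Compound 3 `O=C(NNc1ccnc2cc(Cl)ccc12)c1ccccc1/N=C/c1ccncc1` gives 3.86 in this assay.

All three share the same core and differ only in the ring attached to the carbon that carries a double bond to nitrogen. Compound 2 holds the middle place of the three: compound 1 sits higher by a number 1.25 log units lower from compound 1 to compound 2 (beyond the scatter), and compound 3 sits lower by a number 1.11 log units lower from compound 2 to compound 3 (beyond the scatter). The whole span from the dichlorophenyl to the pyridinyl ring is a number 2.36 log units lower from compound 1 to compound 3 (beyond the scatter).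

Compound 4 `O=C(NNc1ccnc2cc(Cl)ccc12)c1ccccc1/N=C/c1cc2ccccc2[nH]c1=O` is not yet measured. The change from compound 2 is a group of 11 heavy atoms (9 carbon, 1 nitrogen, 1 oxygen; one six-membered aromatic ring of carbon only, one six-membered aromatic ring with 1 hetero atom) in place of a group of 10 heavy atoms (8 carbon, 2 oxygen; one six-membered aromatic ring of carbon only), on a carbon with a double bond to nitrogen. The two measured steps that start or end at compound 2 show that replacing this ring moves the number by more than a single unit in either direction. The entering group brings a hydrogen-bond donor and one acceptor fewer, alongside an extra fused ring, so compound 4 is expected to land somewhat under compound 2, by a number 0.47 log units lower from compound 2 to compound 4 (beyond the scatter), and clearly above compound 3. The estimate for compound 4 in this assay is 4.5, with a range from 3.9 to 5.1.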

Compound 4, partition coefficient: 4.65
Beside the measured number, compound 4's estimate is 0.15 log units below it; low and high end bracket the measured number.
By their numbers in this assay, from the lowest: compound 3; then compound 4; then compound 2; then compound 1.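

At this position, on a carbon with a double bond to nitrogen, a group with more heavy atoms does not have to give a higher number: in this assay, the fused bicyclic group that replaces 3,4-dimethoxyphenyl gives a number 0.32 log units lower from compound 2 to compound 4 (beyond the scatter). Heavy-atom count alone does not put the four compounds in order: replacing pyridin-4-yl with the fused group gives a number 0.79 log units higher from compound 3 to compound 4 (beyond the scatter), yet replacing 2,4-dichlorophenyl, which has fewer heavy atoms than the fused group, gives a number 1.57 log units lower from compound 1 to compound 4 (beyond the scatter). No measurement is available to explain why the numbers fall in this order.

The fused group differs from 3,4-dimethoxyphenyl in its ring count, its hydrogen-bond donor and its hetero atoms all at once, so the compounds shown leave open which of these differences goes with the step. They also leave open where the number would fall with an amine, a carboxylic acid or a longer alkyl chain on this same carbon.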